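The source may report more compounds than this note shows. Statements on the series, on what has been measured and on what is new or still open speak of the compounds shown alone.

Of the compounds shown here, two sharing one brominated core have so far been measured in a functional assay on MCF7 cells (Homo sapiens) for antiproliferative activity, read by MTT assay, with a stated time of 24 h, tested at 50 uM; on this read-out lower numbers stand for a stronger effect and higher numbers for a weaker effect at the one concentration tested. Compound 1, `OC(CCn1nc2c(Br)c(Br)c(Br)c(Br)c2n1)c1cccc(Br)c1`, gives 14% in this assay, a low read-out that stands for a strong effect at the single concentration tested. Compound 2, `C[C@@H](O)CCn1nc2c(Br)c(Br)c(Br)c(Br)c2n1`, gives 102% in this assay, the highest of the two numbers; its nearest neighbour is compound 1, and the gap between them lies beyond the scatter, so compound 2 is the weaker of the pair on this read-out. Within the data shown here, the two compounds differ in more than one place, and no single step connects them.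

Compound 3, `C[C@H](O)CCn1nc2c(Br)c(Br)c(Br)c(Br)c2n1`, is the next compound to be measured. Compared with compound 2, (the two compounds have the same atoms and bonds and differ only in configuration as drawn: 1 of 1 stereo elements differ; a stereocentre at a saturated chain carbon is drawn R in compound 2 and S in compound 3). The two compounds hold the same atoms and bonds, and because compound 2 sits at 102% the step from compound 2 to compound 3 in this assay is expected to be small, with no direction claimed beyond the scatter, as a number 6 percentage points lower from compound 2 to compound 3 (within the scatter) expresses. Compound 3 is therefore estimated to give 96% in this assay, with a likely range from 72% to 110%.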

Compound 3, a percentage reported as activity, at one concentration (the size of the read-out at that concentration, not a potency): 105%
Beside the measured number, compound 3's estimate is 9 percentage points below it; the range from low to high includes it.
By their numbers in this assay, from the lowest: compound 1; then compounds 2 and 3 (each within the scatter of the next).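

In this assay, turning the stereocentre at the saturated chain carbon from R to S amounts to a number 3 percentage points higher from compound 2 to compound 3 (within the scatter). Among these compounds, at this carbon, and with this chain on the shared core, the drawn configuration therefore does not separate the two compounds on this read-out at the one concentration tested, which is something the earlier compounds alone could not show. This is the first pair in the series that can be read as a single step, and the comparison rests on one feature only: the fact that compounds 2 and 3 differ only in the configuration as drawn

The compounds shown leave open whether configuration at this carbon would count for as little in a compound carrying the bromophenyl group of compound 1, whose stereocentre is drawn without a configuration. They also leave open what an amine or a carboxylic acid in place of the hydroxyl group, or a longer chain, would give in this assay, and whether the R and S forms would stay as close at other concentrations.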